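Pyrimidin-4-yl in Place of Pyridin-4-yl

The compounds below may be only part of what the source reports. "The series", "measured", "known", "first", "only" and "open" are said of these compounds alone.

Of the compounds shown here, three built on one shared core have been tested in a functional assay for activation of Alpha-1B adrenergic receptor (Homo sapiens), read by calcium flux; a lower number here means that less compound is needed, a higher number that more compound is needed for the effect. Compound 1 `c1ccc(-c2ccncc2)c(OCC2=NCCN2)c1` carries a pyridin-4-yl group on an aromatic carbon of a six-membered aromatic ring of carbon only. In this assay compound 1 gives only a limit, < 100000 nM, and not a definite number. Compound 2 `Cc1cccnc1-c1ccccc1OCC1=NCCN1` is likewise reported in this assay only as a limit, < 100000 nM. Compound 3 `Cc1ccnc(-c2ccccc2OCC2=NCCN2)c1` also stands in this assay at a limit, < 100000 nM. Among the compounds with values here, all three values sit at the same place, namely (the limit of < 100000 nM in this assay, at which 3 of the 3 values shown sit), so no step between any two of them can be sized, and nothing can be said about which of them needs less compound for the effect.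

The compound still to be measured is compound 4 `c1ccc(-c2ccncn2)c(OCC2=NCCN2)c1`. It differs from compound 1 in one place: pyrimidin-4-yl in place of pyridin-4-yl on an aromatic carbon. Within the data shown here, no measured pair resembles this change, so the expectation rests on the limit of compound 1 alone. The step that the limit leaves unreadable from compound 1 to compound 4 is expected to be none beyond the scatter. For compound 4 the estimate in this assay is 10000 nM, with a range from 500 nM to 100000 nM, and a real chance that the assay again reports only a limit.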

Compound 4, half-maximal effective concentration: < 100000 nM
Compound 4 was reported as a limit; the forecaster's own chance of this, stated with the estimate: 50%; the middle value lies beyond the limit too.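

In this assay compound 4, like compound 1, is reported only as a limit, so the step from pyridin-4-yl to pyrimidin-4-yl cannot be read: the limit of < 100000 nM in this assay, at which 4 of the 4 values shown sit.

The compounds shown leave open how much of any of them is needed for the effect, and whether pyrimidin-4-yl in place of pyridin-4-yl changes that amount at all.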